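The compounds below may be only part of what the source reports. "The series", "measured", "known", "first", "only" and "open" are said of these compounds alone.

Compound 1 `COc1ccc2nccc(CC[C@H]3OC[C@H](NCc4cc5c(cn4)OCCO5)CO3)c2c1` and compound 2 `COc1ccc2nccc(CC[C@H]3OC[C@H](NCc4ccc5c(c4)OCCO5)CO3)c2c1` share one core and differ in a single group sitting on a saturated chain carbon bound to an amine nitrogen. The difference is a group of 10 heavy atoms (8 carbon, 2 oxygen; one six-membered non-aromatic ring with 2 hetero atoms, one six-membered aromatic ring of carbon only) in place of a group of 10 heavy atoms (7 carbon, 1 nitrogen, 2 oxygen; one six-membered non-aromatic ring with 2 hetero atoms, one six-membered aromatic ring with 1 hetero atom), on a saturated chain carbon bound to an amine nitrogen. In an ADME assay on K562 cells (Homo sapiens) for antiproliferative activity (on this read-out lower numbers stand for stronger inhibition and higher numbers for weaker inhibition), compound 1 gives 40000 nM, while compound 2 gives 7400 nM; that single swap produced a 5.4-fold lower number from compound 1 to compound 2 (0.73 log units; beyond the scatter).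

Compound 3 `COc1ccc2nccc(CC[C@H]3CC[C@H](NCc4cc5c(cn4)OCCO5)CC3)c2c1` carries the same group as compound 1, but on a different core; the difference between the two cores is not broken down here. In this assay compound 3 gives 7500 nM. Within the data shown here, that number sits within the scatter of the one from compound 2, and it is clearly lower than the one from compound 1.

Compound 4 `COc1ccc2nccc(CC[C@H]3CC[C@H](NCc4ccc5c(c4)OCCO5)CC3)c2c1` has not yet been measured. It stands to compound 3 exactly as compound 2 stands to compound 1: the change is a group of 10 heavy atoms (8 carbon, 2 oxygen; one six-membered non-aromatic ring with 2 hetero atoms, one six-membered aromatic ring of carbon only) in place of a group of 10 heavy atoms (7 carbon, 1 nitrogen, 2 oxygen; one six-membered non-aromatic ring with 2 hetero atoms, one six-membered aromatic ring with 1 hetero atom), on a saturated chain carbon bound to an amine nitrogen, the same change at the same place. Only one measured instance of this change exists among these compounds, so any expectation rests on that one step alone. For compound 4 a step of roughly the same size, a 4.7-fold lower number from compound 3 to compound 4 (0.67 log units; beyond the scatter), is expected in this assay, since the earlier instance gave a 5.4-fold lower number from compound 1 to compound 2 (0.73 log units; beyond the scatter). On that basis the value of compound 4 is estimated at 1600 nM, with a likely range from 600 nM to 4500 nM.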

Compound 4, half-maximal inhibitory concentration: 4200 nM
Compound 4: the middle estimate sits 2.6-fold (0.42 log units) below what was measured; the measured number falls inside the stated range.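

In this assay, putting 2,3-dihydro-1,4-benzodioxin-6-yl in place of the nitrogen-containing group on the core of compound 3 gives a 1.8-fold lower number from compound 3 to compound 4 (0.25 log units; within the scatter), so on this core the effect of the swap cannot be told apart from ordinary variation in repeated measurements. Set beside the first instance of the same swap, the step does not carry over at the same size from one core to the other: the same change on two cores in this assay, a 5.4-fold lower number (0.73 log units; beyond the scatter) from compound 1 to compound 2 and a 1.8-fold lower number (0.25 log units; within the scatter) from compound 3 to compound 4, 3.0-fold (0.48 log units) apart, beyond the scatter of two such steps The result therefore shows that, for these two pairs, the size of the step depends on the core that carries the group, but it does not show why, and two pairs give no rule that could be applied to any further core.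

The compounds shown leave open how large this step would be on a third core, and which part of the difference in the two cores goes with the change in its size. They also leave open how simpler groups, such as a plain phenyl ring or a pyridine ring, would behave on a saturated chain carbon bound to an amine nitrogen on either core.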